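Adding a second methoxy group to a benzyl arm

The compounds below may be only part of what the source reports. "The series", "measured", "known", "first", "only" and "open" are said of these compounds alone.

Measured so far:
- compound 1, `COc1ccc(Cn2c(CCc3c[nH]c4ccccc34)nnc2[C@H](NC(=O)C(C)(C)N)c2c[nH]c3ccccc23)c(OC)c1`: 108 nM
- compound 2, `COc1ccc(Cn2c(CCc3ccccc3)nnc2[C@H](NC(=O)C(C)(C)N)c2c[nH]c3ccccc23)cc1`: 11 nM

Both compounds were tested in an in vitro assay on LLC-PK1 cells for displacement of a labelled ligand from growth hormone secretagogue receptor type 1 (Homo sapiens); on this read-out higher numbers stand for weaker inhibition and lower numbers for stronger inhibition. Compound 1 gives 108 nM, and compound 2 gives 11 nM. Of the two numbers, compound 2 has the lower one, and the gap between compound 2 and compound 1 lies well beyond the usual scatter of such measurements. The two compounds differ in more than one place, so the gap cannot be tied to any single change.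

Compound 3, `COc1ccc(Cn2c(CCc3ccccc3)nnc2[C@H](NC(=O)C(C)(C)N)c2c[nH]c3ccccc23)c(OC)c1`, has not yet been measured. It differs from compound 2 in one place: methoxy in place of hydrogen on an aromatic carbon, ortho to a large group and meta to a methoxy group. Compound 1 carries this same 2,4-dimethoxybenzyl arm, but it also carries a different second arm, so it gives no clean guide. Among the measured compounds shown here, with no isolated step to lean on, the expected change from compound 2 to compound 3 is a 1.4-fold higher number from compound 2 to compound 3 (0.13 log units; within the scatter), a small move, if any, that may stay within the scatter. Compound 3 is therefore expected to give about 15 nM, within the range from 5 nM to 50 nM.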

Compound 3, half-maximal inhibitory concentration: 60 nM
Estimate against measurement, compound 3: 4.0-fold (0.60 log units) below; the whole stated range lies below it.
By their numbers in this assay, from the lowest: compound 2; then compounds 3 and 1 (each within the scatter of the next).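

In this assay, the step with methoxy in place of hydrogen on an aromatic carbon, ortho to a large group and meta to a methoxy group, is a 5.5-fold higher number from compound 2 to compound 3 (0.74 log units; beyond the scatter) and so weakens inhibition. The second arm stays the same across this step, and the change can now be read on its own. With the 2,4-dimethoxybenzyl arm held fixed, phenyl in place of 1H-indol-3-yl on a saturated chain carbon gives a 1.8-fold lower number from compound 1 to compound 3 (0.26 log units; within the scatter) and stays within the usual scatter, so this swap shows no clear effect on that background. Nothing measured here explains why the added methoxy weakens inhibition.

Placing a fluorine atom, a hydroxyl group or an ethoxy group at the same aromatic carbon would help to show whether the weakening is specific to methoxy or extends to other groups there. It also remains open whether this methoxy has the same effect alongside the 1H-indol-3-yl arm, since the compounds shown offer no partner for compound 1 that lacks it.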